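Chloro for Bromo on Two Cores in Cytotoxicity Testing

This account rests on a few compounds, and the source may have more. Where it says the series, first, only, none or still open, it means among the compounds named here.

Compound 1 `COC(=O)c1c[nH]c2cc(OCCOc3ccccc3)c(Cl)cc2c1=O` and compound 2 `COC(=O)c1c[nH]c2cc(OCCOc3ccccc3)c(Br)cc2c1=O` share one core and differ in one place only. In an ADME assay on J774 cells (Mus musculus) for cytotoxicity (a higher number here means that more compound is needed for the effect, a lower number that less compound is needed), compound 1 gives > 20000 nM, which is a limit of the assay and not a number. In this assay compound 2 likewise gives the limit > 20000 nM. The step that the two limits leave unreadable from compound 2 to compound 1, the change (chloro in place of bromo on an aromatic carbon), therefore cannot be read, both values sitting at the limit of > 20000 nM in this assay, at which 2 of the 3 values shown sit.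

Compound 3 `CCCCc1cc2c(=O)c(Br)c(C)[nH]c2cc1OCCOc1ccccc1` carries a different core; the difference between the two cores is not broken down here. In this assay compound 3 gives > 10000 nM, again a limit rather than a number, as the limit of > 10000 nM in this assay, at which 1 of the 3 values shown sits, shows.

Compound 4 `CCCCc1cc2c(=O)c(Cl)c(C)[nH]c2cc1OCCOc1ccccc1` is compound 3 with the same kind of change, (chloro in place of bromo on an aromatic carbon). Around the place, this ring holds 1 nitrogen, and the site is ortho to a group of 1 heavy atom and to a methyl group, two atoms from the ring nitrogen, whereas in compound 2 the ring is of carbon only and the site is ortho to a large group. The step that the limit leaves unreadable from compound 3 to compound 4 is expected to be small. That expectation rests on compound 3, whose limit in this assay was > 10000 nM. Compound 4 is estimated at 20000 nM, between 10000 nM and 60000 nM.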

Compound 4, half-maximal effective concentration: > 10000 nM
Compound 4: no number, only a limit; the forecaster's own chance of this, stated with the estimate: 90%; the middle value lies beyond the limit too.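

In this assay compound 4 gives > 10000 nM, a limit and not a number. Compound 3 also stands at a limit, so the change from bromo to chloro between compound 3 and compound 4 cannot be read. The compounds shown leave open whether chloro and bromo differ in this read-out on either core.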